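From vinyl to cyclopropylmethyl on a benzylated core

The compounds below may be only part of what the source reports. "The series", "measured", "known", "first", "only" and "open" are said of these compounds alone.

In a functional assay on HL-60 cells (Homo sapiens) for antiproliferative activity, read by MTT assay (on this read-out lower numbers stand for stronger inhibition and higher numbers for weaker inhibition), compound 1 (`C=C[C@@H]1O[C@H](COCc2ccccc2)[C@@H](OCc2ccccc2)[C@H](OCc2ccccc2)[C@H]1O`) gives 11800 nM and holds the lowest of the two numbers available. Compound 3 (`O[C@@H]1[C@@H](OCc2ccccc2)[C@H](O)[C@@H](COCc2ccccc2)O[C@H]1Cc1ccccc1`) stands higher at 35300 nM, a gap beyond the scatter, while compound 2 (`CC(=O)O[C@@H]1[C@@H](OCc2ccccc2)[C@H](OCc2ccccc2)[C@@H](COCc2ccccc2)O[C@H]1Cc1ccccc1`) is recorded as "not active" (no number reported) with no number. Compound 4 (`O[C@@H]1[C@@H](OCc2ccccc2)[C@H](OCc2ccccc2)[C@@H](COCc2ccccc2)O[C@H]1CC1CC1`) keeps the core of compound 1 but carries cyclopropylmethyl in place of vinyl on a saturated ring carbon. Among the compounds with values here, no measured pair isolates this change. Compound 3 also lacks the vinyl and reads 35300 nM, so a modest move toward a higher number is expected in this assay, perhaps hardly beyond the scatter. The expected step is a 1.5-fold higher number from compound 1 to compound 4 (0.18 log units; within the scatter) and remains uncertain. For compound 4 the estimated value is 18000 nM (expected range 7000 nM to 45000 nM) on this evidence.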

Compound 4, half-maximal inhibitory concentration: "not active" (no number reported)
Compound 4: no number reported; the estimate stays without a comparison.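

Compound 4 carries no number in this assay, so no step from compound 1 to compound 4 can be read, and no evidence on hand explains this result. Going by these compounds, how far cyclopropylmethyl in place of vinyl alone shifts activity stays open.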